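The source may hold more compounds than are shown below. What is called first, only, known or untested is meant among the compounds shown, and "the series" means these compounds.

Of the compounds shown here, three built on one shared core have so far been tested in a functional assay on MDA-MB-231 cells (Homo sapiens) for cytotoxicity, read by MTT assay, with a stated time of 48 h; on this read-out lower numbers stand for stronger inhibition and higher numbers for weaker inhibition. Compound 1 `Cc1ccc(Cn2c(/C=C3\SC(=S)N(CC(=O)O)C3=O)nc3cc(Cl)ccc32)cc1` gives 13700 nM. Compound 3 `Cc1ccc(Cn2c(/C=C3\SC(=S)N(CC(=O)O)C3=O)nc3cc(F)ccc32)cc1` gives 6550 nM. Compound 2 `Cc1ccc(Cn2c(/C=C3\SC(=S)N(CC(=O)O)C3=O)nc3ccc(Cl)cc32)cc1` gives 3960 nM; how the core of compound 2 differs from the core of compound 1 is not broken down here, and the values of compound 2 and compound 3 lie within the usual scatter of each other. Among the measured compounds shown here, from compound 1 to compound 3 the only change is fluoro in place of chloro on an aromatic carbon That change made a 2.1-fold lower number from compound 1 to compound 3 (0.32 log units; beyond the scatter).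

Compound 4 `Cc1ccc(Cn2c(/C=C3\SC(=S)N(CC(=O)O)C3=O)nc3ccc(F)cc32)cc1` has not yet been measured in this assay. It relates to compound 2 exactly as compound 3 relates to compound 1: fluoro in place of chloro on an aromatic carbon The surroundings of the change are described in the same words for both pairs, so it counts as the same change. A step of similar size is expected for compound 4, namely a 1.8-fold lower number from compound 2 to compound 4 (0.26 log units; within the scatter), because a 2.1-fold lower number from compound 1 to compound 3 (0.32 log units; beyond the scatter) was seen for this change once before. On that single precedent, compound 4 is estimated at 2200 nM, with a likely range from 900 nM to 5500 nM.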

Compound 4, half-maximal inhibitory concentration: 3860 nM
Compound 4: the middle estimate sits 1.8-fold (0.24 log units) below what was measured, and the stated range covers the measured number.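

On the second core, putting fluoro in place of chloro gave a 1.0-fold lower number from compound 2 to compound 4 (0.01 log units; within the scatter), so in this assay this pair shows no readable change, whereas the same swap on the first core gave a step just beyond the scatter. Set side by side, the two steps cannot be told apart: the same change on two cores in this assay, a 2.1-fold lower number (0.32 log units; beyond the scatter) from compound 1 to compound 3 and a 1.0-fold lower number (0.01 log units; within the scatter) from compound 2 to compound 4, 2.0-fold (0.31 log units) apart, within the scatter of two such steps This means the results fit a single small step shared by both cores, but they do not prove that the step carries over, and with only two pairs they cannot show that the core alters it either.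

The compounds shown carry only chloro or fluoro on this aromatic carbon, so it remains open what a larger or quite different group there, such as a nitrile, a methoxy group or an amine, would do to the number. As far as these compounds go, it also remains open whether this swap would give a clear step on any further core.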